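The compounds below may be only part of what the source reports. "The series", "measured", "known", "first", "only" and "open" are said of these compounds alone.

Compound 1, `Oc1ccc(-c2nc3ncccn3c2NC2CCCCC2)cc1`, in a toxicity assay on A549 cells (Homo sapiens) for cytotoxicity, read by luminescence and CellTiter-Glo, with a stated time of 48 h (a higher number here means that more compound is tolerated, a lower number that less compound is tolerated), gives > 100000 nM, which is a limit of the assay and not a number.
Compound 2, `COc1ccc(-c2nc3ncccn3c2NC2CCCCC2)cc1`, in this assay gives > 100000 nM, again a limit of the assay.
Compound 3, `Oc1ccccc1-c1nc2ncccn2c1NC1CCCCC1`, in this assay gives > 100000 nM, once more a limit of the assay.

All three measured compounds therefore sit at the same point: the limit of > 100000 nM in this assay, at which 3 of the 3 values shown sit. None of them shows cytotoxicity within the range the assay can report, so the steps between them cannot be sized. From compound 1 to compound 2 the step reads a step that the two limits leave unreadable from compound 1 to compound 2; the change behind it is methyl in place of hydrogen on an oxygen on an aromatic ring. From compound 1 to compound 3 the step reads a step that the two limits leave unreadable from compound 1 to compound 3, and from compound 2 to compound 3 it reads a step that the two limits leave unreadable from compound 2 to compound 3. The two cores differ as 2-hydroxyphenyl in place of 4-hydroxyphenyl on an aromatic carbon.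

Compound 4, `COc1ccccc1-c1nc2ncccn2c1NC1CCCCC1`, has not yet been measured in this assay. It differs from compound 3 as methyl in place of hydrogen on an oxygen on an aromatic ring. The place of this change reads the same, word for word, as in the change from compound 1 to compound 2, so the two are the same kind of change. The first instance gave no readable step, since compound 1 and compound 2 both sit at the limit. The step from compound 3 to compound 4 is expected to be a number no higher from compound 3 to compound 4 (the limit leaves the size open), resting on compound 3 sitting at the limit and on the earlier change leaving compound 2 at the limit as well. Compound 4 is therefore estimated at 100000 nM, with a plausible span from 50000 nM to 300000 nM.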

Compound 4, half-maximal cytotoxic concentration: > 100000 nM
Compound 4: only a limit was reported; the forecaster's own chance of this, stated with the estimate: 80%; the middle value sits exactly at the limit.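

In this assay compound 4 gives > 100000 nM which is a limit of the assay and not a number. The steps joining compound 4 to compound 1, compound 2 and compound 3 therefore cannot be read, since all four compounds sit at one point: the limit of > 100000 nM in this assay, at which 4 of the 4 values shown sit. The compounds shown leave open what concentration of any of them would actually prove cytotoxic to these cells.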